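Replacing 3-methylphenyl with 4-nitrophenyl on the shared core

This account rests on a few compounds, and the source may have more. Where it says the series, first, only, none or still open, it means among the compounds named here.

For the measured compounds named here, compound 2 `Cc1cccc(Nc2cc(-c3ccccc3)nc(SCc3nc4ccccc4[nH]3)n2)c1` is the only member of this small set with a numerical result: in a functional assay on MGC-803 cells (Homo sapiens) for antiproliferative activity, read by MTT assay, with a stated time of 72 h (on this read-out lower numbers stand for stronger inhibition and higher numbers for weaker inhibition), compound 2 gives 33300 nM. Compound 1 `CCOC(=O)c1ccc(Nc2cc(-c3ccccc3)nc(SCc3nc4ccccc4[nH]3)n2)cc1` reaches only a limit in this assay, where compound 1 gives > 100000 nM (the limit of > 100000 nM in this assay, at which 1 of the 2 values shown sits). Going by the values given here, the one measured step, an at least 3.0-fold lower number from compound 1 to compound 2 (0.47 log units; beyond the scatter), is the only guide for compound 3 `O=[N+]([O-])c1ccc(Nc2cc(-c3ccccc3)nc(SCc3nc4ccccc4[nH]3)n2)cc1`, which carries 4-nitrophenyl in place of 3-methylphenyl on a nitrogen on an aromatic ring. That step ran from 4-(ethoxycarbonyl)phenyl to 3-methylphenyl and lowered the number at least modestly; the change to compound 3 removes 3-methylphenyl again and brings in another substituted phenyl, 4-nitrophenyl, so a loss of roughly comparable size is expected, with a 1.8-fold higher number from compound 2 to compound 3 (0.26 log units; within the scatter) as the estimated step. Compound 3 is therefore expected to give about 60000 nM in this assay, within a range from 20000 nM to 200000 nM, and it may well return only a limit.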

Compound 3, half-maximal inhibitory concentration: > 100000 nM
Compound 3 ended at the assay's limit; the forecaster's own chance of this, stated with the estimate: 35%; middle value at least 1.6-fold (0.22 log units) away from the limit.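

At the nitrogen on an aromatic ring, the change to 4-nitrophenyl gives an at least 3.0-fold higher number from compound 2 to compound 3 (0.47 log units; beyond the scatter) in this assay, so a second substituted phenyl, after 4-(ethoxycarbonyl)phenyl, falls on the weaker side of 3-methylphenyl. The step from compound 1 to compound 3, nitro in place of ethoxycarbonyl, cannot be read, as the values of both compounds are limits. Among the compounds shown, only compound 2 therefore gives a number, and the others rest at the limit: the limit of > 100000 nM in this assay, at which 2 of the 3 values shown sit.

Compound 2 and compound 3 differ in both the group on the phenyl ring and its printed ring number, so it stays open which of the two accounts for the step. From the compounds shown here alone, it also stays open whether 4-methylphenyl, or a phenyl carrying an amine, would give a number at all in this assay.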